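Swapping cyano for carbamoyl on compound 3

A few compounds are considered here, and "the series" means these few. Any claim that something is new, unique, unknown or untested is made for them only; others in the source may bear on it.

Values in an ADME assay (liver) for metabolic stability, with Liver microsome (Homo sapiens) as the target, read by LC-MS, using microsomes and NADPH, with a stated time of 5 min, at 37 degrees C; on this read-out higher numbers stand for fast clearance and lower numbers for slow clearance
Compound 1 (`CCn1c([C@@H](C)NS(=O)(=O)c2ccc(Cl)cc2)nc2ccccc21`): > 100 mL.min-1.g-1 (a limit, not a number)
Compound 2 (`CCn1c([C@@H](C)NS(=O)(=O)c2ccc(Cl)cc2)nc2cc(F)c(Cl)cc21`): > 100 mL.min-1.g-1 (a limit, not a number)
Compound 3 (`CCn1c([C@@H](C)NS(=O)(=O)c2ccc(Cl)cc2)nc2cc(C#N)ccc21`): 71 mL.min-1.g-1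

As far as these compounds go, compound 3 alone carries a real number, and the rest of the series sits at the limit of > 100 mL.min-1.g-1 in this assay, at which 2 of the 3 values shown sit (so its true values are unknown). Compound 4 (`CCn1c([C@@H](C)NS(=O)(=O)c2ccc(Cl)cc2)nc2cc(C(N)=O)ccc21`) differs from compound 3 by one group: carbamoyl in place of cyano on an aromatic carbon. Among the compounds with values here, the only measured step involving either group is an at least 1.4-fold lower number from compound 1 to compound 3 (0.14 log units; that floor lies within the scatter) (cyano in place of hydrogen). It says nothing direct about carbamoyl, so on that slim basis a small fall, perhaps nothing beyond the scatter, is expected in this assay (the direction is tentative). The expected change is a 1.4-fold lower number from compound 3 to compound 4 (0.15 log units; within the scatter) (an estimate only). Compound 4 is estimated at 50 mL.min-1.g-1 (20 mL.min-1.g-1 to 100 mL.min-1.g-1).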

Compound 4, intrinsic clearance in microsomes: < 5 mL.min-1.g-1
Compound 4 gave a limit, no number; the forecaster's own chance of this, stated with the estimate: 10%; at least 10-fold (1.00 log units) between middle value and limit.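

In this assay, carbamoyl in place of cyano gives an at least 14-fold lower number from compound 3 to compound 4 (1.15 log units; beyond the scatter), and carbamoyl in place of hydrogen gives an at least 20-fold lower number from compound 1 to compound 4 (1.30 log units; beyond the scatter). This single position can therefore shift microsomal clearance far more than the cyano step alone revealed, and the group placed there matters greatly. Both steps are floors, since compound 4 stands at a limit of the assay and not at a number: the limit of < 5 mL.min-1.g-1 in this assay, at which 1 of the 4 values shown sits.

As far as these compounds go, whether a carboxylic acid or a methyl ester at this position would give similarly slow clearance remains open. So does whether carbamoyl would have the same effect elsewhere on the shared core.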